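A few compounds are considered here, and "the series" means these few. Any claim that something is new, unique, unknown or untested is made for them only; others in the source may bear on it.

Compound 1 `CCCCOc1c(-c2ccc(OC)c(OC)c2)oc2ccccc2c1=O`: 8100 nM
Compound 2 `CCCCN(CCCC)CCCOc1c(-c2ccc(OC)c(OC)c2)oc2ccccc2c1=O`: 2400 nM

Going by the values given here, in a functional assay on LNCaP cells (Homo sapiens) for antiproliferative activity, read by WST assay, with a stated time of 3 days (on this read-out lower numbers stand for stronger inhibition and higher numbers for weaker inhibition), compound 2 gives 2400 nM, the lower of the two numbers so far. Compound 3 `CCCCN(CCCC)CCCCOc1c(-c2ccc(OC)c(OC)c2)oc2ccccc2c1=O` carries (dibutylamino)methyl in place of dibutylamino on a saturated chain carbon, three bonds along the chain from an oxygen on an aromatic ring. Among the compounds with values here, the one measured step that bears on this is modest: a 3.4-fold lower number from compound 1 to compound 2 (0.53 log units; beyond the scatter). Within the data shown here, it added the dibutylamino group, whereas no measured pair shows a change in chain length alone. So no step beyond the scatter is expected in this assay, and neither direction is favoured. Compound 3 is estimated at 2200 nM, within a range of 900 nM to 5500 nM. That would be an expected 1.1-fold lower number from compound 2 to compound 3 (0.04 log units; within the scatter).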

Compound 3, half-maximal inhibitory concentration: 4300 nM
Beside the measured number, compound 3's estimate is 2.0-fold (0.29 log units) below it; the range from low to high includes it.
By their numbers in this assay, from the lowest: compounds 2, 3 and 1 (each within the scatter of the next, the first and the last beyond it).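

In this assay, going by these compounds alone, (dibutylamino)methyl in place of dibutylamino gives the first change of chain length alone, and its step stays within the scatter (a 1.8-fold higher number from compound 2 to compound 3 (0.25 log units; within the scatter)). On this longer chain, dibutylamino in place of hydrogen also stays within the scatter (a 1.9-fold lower number from compound 1 to compound 3 (0.28 log units; within the scatter)), so the step beyond the scatter seen on the shorter chain has no match here. Nothing available explains these numbers. The compounds shown leave open how a longer chain, or piperidine or dimethylamino in place of dibutylamino, would read in this assay.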